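A few compounds are considered here, and "the series" means these few. Any claim that something is new, unique, unknown or untested is made for them only; others in the source may bear on it.

Measured in an ADME assay (serum, Bos taurus) for metabolic stability, read by HPLC; a lower number here means that the compound disappears faster, a higher number that the compound lasts longer:
- compound 1 `CCCC(CCC)C(=O)OC[C@H]1O[C@@H](n2cnc3c(N)ncnc32)[C@H](OC(=O)C(CCC)CCC)[C@]1(C)O` gives > 72 h (a limit)
- compound 2 `CCCC(CCC)C(=O)O[C@H]1[C@H](n2cnc3c(N)ncnc32)O[C@H](CO)[C@@]1(C)O` gives > 72 h (a limit)

Compound 1 has only a limit and no number in this assay (the same is true of compound 2), and both readings sit at the limit of > 72 h in this assay, at which 2 of the 2 values shown sit (no size can be taken from them). Compound 3 `CCCC(CCC)C(=O)OC[C@H]1O[C@@H](n2cnc3c(N)ncnc32)[C@H](O)[C@]1(C)O` remains to be measured. It differs from compound 1 by hydrogen in place of (1-propylbutyl)carbonyl on an oxygen on a saturated carbon (the shared core stays unchanged). Within the data shown here, the one measured step of this kind is a step that the two limits leave unreadable from compound 1 to compound 2 (it offers no size to carry over), so no change beyond the scatter is expected. The estimated step is a step that the limit leaves unreadable from compound 1 to compound 3 (with no firm direction expected). Compound 3 is expected at 80 h (estimated range 36 h to 160 h), quite possibly reported as a limit again.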

Compound 3, half-life in the serum assay: > 72 h
Compound 3 ended at the assay's limit; the forecaster's own chance of this, stated with the estimate: 70%; the middle value does not contradict the limit.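

Among these compounds, compound 1 and compound 3 give only limits in the serum assay and in a physicochemical assay for metabolic stability, read by HPLC, in phosphate buffer, at 37 degrees C, at pH 7.4 (on this read-out higher numbers stand for a longer-lived compound and lower numbers for a shorter-lived compound), and no step between them can be read. In the physicochemical assay compound 1 gives > 72 h as a limit. In the physicochemical assay compound 3 gives > 72 h as a limit. Still open are the actual half-lives of these compounds and whether hydrogen in place of (1-propylbutyl)carbonyl shifts them at all.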